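Methoxy ribonucleoside: from ethynyl to furan-2-yl

The compounds below may be only part of what the source reports. "The series", "measured", "known", "first", "only" and "open" are said of these compounds alone.

Measured compounds in a functional assay on A549 cells (Homo sapiens), read by MTT assay, with a stated time of 72 h; on this read-out lower numbers stand for stronger inhibition and higher numbers for weaker inhibition:
Compound 1, `C#Cc1cn([C@@H]2O[C@H](CO)[C@@H](O)[C@H]2O)c2ncnc(N(C)C)c12`: 390 nM
Compound 2, `C#Cc1cn([C@@H]2O[C@H](CO)[C@@H](O)[C@H]2O)c2ncnc(OC)c12`: 8160 nM
Compound 3, `C#Cc1cn([C@@H]2O[C@H](CO)[C@@H](O)[C@H]2O)c2ncnc(SC)c12`: 140 nM

Compound 2 gives the highest number of the three in this assay. Its nearest neighbour is compound 1, reached by a 21-fold higher number from compound 1 to compound 2 (1.32 log units; beyond the scatter), and the furthest is compound 3, reached by a 58-fold lower number from compound 2 to compound 3 (1.77 log units; beyond the scatter). Both measured steps, and the third one, a 2.8-fold lower number from compound 1 to compound 3 (0.44 log units; beyond the scatter), concern only the group on the aromatic carbon that carries dimethylamino, methoxy or methylsulfanyl.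

Compound 4, `COc1ncnc2c1c(-c1ccco1)cn2[C@@H]1O[C@H](CO)[C@@H](O)[C@H]1O`, keeps the methoxy of compound 2 and changes a different place: furan-2-yl in place of ethynyl on an aromatic carbon. Going by the values given here, no measured step touches the ethynyl group, so none of the three steps bears directly on this change, and the size of the effect in this assay cannot be read from the measured compounds. The estimate for compound 4 therefore stays close to compound 2, with a wide range, and its expected value is 4000 nM (range 800 nM to 20000 nM). This expectation corresponds to a step of a 2.0-fold lower number from compound 2 to compound 4 (0.31 log units; beyond the scatter), which is taken to be uncertain in direction.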

Compound 4, half-maximal inhibitory concentration: 30 nM
The estimate for compound 4 lay 130-fold (2.12 log units) above the measured number; the measured number lies below the stated range.
By their numbers in this assay, from the lowest: compound 4; then compound 3; then compound 1; then compound 2.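

In this assay, the three earlier compounds all kept ethynyl and varied only the group on the other aromatic carbon, so they gave no view of what the ethynyl-bearing carbon could tolerate; compound 4 shows that this place on the five-membered aromatic ring with 1 nitrogen can also shift the number strongly. With the methoxy group held constant, replacing ethynyl by furan-2-yl gives a 270-fold lower number from compound 2 to compound 4 (2.43 log units; beyond the scatter), a step that exceeds in size the largest change seen at the other place, a 58-fold lower number from compound 2 to compound 3 (1.77 log units; beyond the scatter), and shows that a larger aromatic ring is not only tolerated here but goes with a much lower number. The data shown offer no measured explanation for this effect of the furan-2-yl group.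

The compounds shown leave open whether furan-2-yl brings a step of similar size when methylsulfanyl or dimethylamino replaces methoxy on the other aromatic carbon. They also leave open whether the result is particular to furan-2-yl or would extend to other groups at this place, such as thiophen-2-yl, phenyl or a simple methyl.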